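The source may report more compounds than this note shows. Statements on the series, on what has been measured and on what is new or still open speak of the compounds shown alone.

Measured so far:
compound 1 `CCCc1ccc2nc(N)sc2c1` — 6 mg/kg
compound 2 `CCCCCCc1ccc2nc(N)sc2c1` — 7 mg/kg
compound 3 `Cn1c(=N)sc2cc(OC(F)(F)F)ccc21` — 5 mg/kg

In a functional assay on the whole organism with Rattus norvegicus as the target (a higher number here means that more compound is needed for the effect, a lower number that less compound is needed), compound 3 gives the lowest of the three numbers, but its gaps to compound 1 and to compound 2 both lie within the scatter, so no order among the three can be read. For the measured compounds named here, the only measured step, a 1.2-fold higher number from compound 1 to compound 2 (0.07 log units; within the scatter), is within the scatter and concerns a chain at another place on the shared core, so it gives no direct guide to the change at hand. Compound 4 `C[S+]([O-])Cn1c(=N)sc2cc(OC(F)(F)F)ccc21` differs from compound 3 by a group of 3 heavy atoms (1 carbon, 1 oxygen, 1 sulfur; no ring) in place of a hydrogen atom, on a saturated chain carbon bound to an aromatic nitrogen. Going by the values given here, no measured pair shows a change of this kind, so no step beyond the scatter is expected in this assay. For compound 4 the estimate is 6 mg/kg, with a range of 3 mg/kg to 14 mg/kg. The expected step is therefore a 1.2-fold higher number from compound 3 to compound 4 (0.08 log units; within the scatter).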

Compound 4, dose for half-maximal effect: 2.3 mg/kg
Compound 4: middle estimate off by 2.6-fold (0.42 log units), on the high side, and the stated range ends above it.
By their numbers in this assay, from the lowest: compound 4; then compounds 3, 1 and 2 (each within the scatter of the next).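

In this assay, for the compounds shown here, the group of 3 heavy atoms (1 carbon, 1 oxygen, 1 sulfur; no ring) on a saturated chain carbon bound to an aromatic nitrogen gives the only step beyond the scatter (a 2.2-fold lower number from compound 3 to compound 4 (0.34 log units; beyond the scatter)). Going by these compounds alone, the step is modest, but it shows that the number at this place can respond to a change, which the earlier compounds, all within the scatter of one another, did not show.

Going by these compounds, whether a longer chain, an amine or a carboxylic acid at this place would give a similar step remains open, as does whether the sulfur or the oxygen matters for it. No evidence on hand bears on the reason for this step.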